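A Branched Ring Opened to a Straight Chain

A few compounds are considered here, and "the series" means these few. Any claim that something is new, unique, unknown or untested is made for them only; others in the source may bear on it.

Compound 1 `CC1(C[C@@H](O)C(=O)N2[C@@H]3C[C@@H]3C[C@H]2C(=O)NCc2cc(Cl)ccc2-n2cnnn2)CC1` carries a 1-methylcyclopropyl group on the chain that bears the hydroxyl. In a functional assay on a cell-free system (plasma, Homo sapiens), with a stated time of 3 min (a higher number here means a weaker inhibitor, a lower number a stronger inhibitor), compound 1 gives 1300 nM. Compound 2 `O=C(NCc1cc(Cl)ccc1-n1cnnn1)[C@@H]1CCON1C(=O)[C@H](O)c1ccccc1`, built on a different core, gives 1500 nM in this assay, a number that sits within the scatter of compound 1. Compound 3 `CCCC[C@@H](O)C(=O)N1[C@@H]2C[C@@H]2C[C@H]1C(=O)NCc1cc(Cl)ccc1-n1cnnn1` differs from compound 1 by a single exchange: propyl in place of 1-methylcyclopropyl on a saturated chain carbon, two bonds along the chain from a carbonyl carbon and an oxygen on a saturated carbon. Among the compounds with values here, no measured pair shows this change, so a step from compound 1 to compound 3 of about a 1.4-fold higher number from compound 1 to compound 3 (0.14 log units; within the scatter) is expected, with no shift beyond the scatter. For compound 3 a value of about 1800 nM is estimated, between 600 nM and 5000 nM.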

Compound 3, half-maximal inhibitory concentration: 870 nM
Compound 3: the middle estimate sits 2.1-fold (0.32 log units) above what was measured, and the stated range covers the measured number.
By their numbers in this assay, from the lowest: compounds 3, 1 and 2 (each within the scatter of the next).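

In this assay the exchange of 1-methylcyclopropyl for propyl gives a 1.5-fold lower number from compound 1 to compound 3 (0.17 log units; within the scatter). This shows what compound 1 and compound 2 alone could not: at this position, an open chain can take the place of the branched ring with no shift beyond the scatter. Nothing available explains this result. Going by these compounds, whether a longer chain, an amine or a carboxylic acid at this place would also stay within the scatter remains open. So does whether the same exchange would read alike on the core of compound 2.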